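A few compounds are considered here, and "the series" means these few. Any claim that something is new, unique, unknown or untested is made for them only; others in the source may bear on it.

Two measured compounds frame this step. Compound 1 `COc1ccc(-c2nc(C(F)(F)F)sc2N2CCN(C(=O)Cn3cnc4cccnc43)[C@H](C)C2)cc1` gives 131 nM in a functional assay on U2OS cells for antagonist activity at C-X-C chemokine receptor type 3 (Homo sapiens), read by beta-arrestin recruitment; a lower number here means a stronger inhibitor, a higher number a weaker inhibitor. Compound 2 `Cc1nc(C)n(CC(=O)N2CCN(c3sc(C(F)(F)F)nc3-c3cnc(OC(C)C)nc3)C[C@H]2C)n1` gives 138 nM in this assay; that is the higher of the two numbers, but the gap to compound 1 lies within the scatter, so the two compounds cannot be told apart on these figures.

Compound 3 `CCCc1ncc(-c2nc(C(F)(F)F)sc2N2CCN(C(=O)Cn3nc(C)nc3C)[C@H](C)C2)cn1` differs from compound 2 in one place: propyl in place of isopropoxy on an aromatic carbon. Among the compounds with values here, no comparable step between measured compounds is available, so there is nothing in the numbers themselves to say how this change acts. With the two measured compounds sitting at about the same level, the expectation is a step of a 1.3-fold higher number from compound 2 to compound 3 (0.12 log units; within the scatter) from compound 2 to compound 3 in this assay, which stays within the scatter. Compound 3 is therefore estimated at 180 nM in this assay, with a range from 70 nM to 450 nM.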

Compound 3, half-maximal inhibitory concentration: 258 nM
For compound 3 the middle estimate is 1.4-fold (0.16 log units) below the measured one; the measured number falls inside the stated range.
By their numbers in this assay, from the lowest: compounds 1, 2 and 3 (each within the scatter of the next).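

In this assay the exchange of 2-isopropoxypyrimidin-5-yl for 2-propylpyrimidin-5-yl gives a 1.9-fold higher number from compound 2 to compound 3 (0.27 log units; within the scatter) and so does not separate the two compounds. Within the data shown here, this is the first step that can be read at this position, between two ring nitrogen atoms and para to a large group. There, a propyl group with no hydrogen-bond acceptor takes the place of an isopropoxy group with one, and the step stays within the scatter; no evidence is available on why this is so.

On these data alone, what an amine, a cyclopropyl group or a longer chain such as pentyl would do at this position remains open. Also open, as far as these compounds go, is whether the same exchange would give a similar step if the rest of compound 2 were different.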